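Series notes: chloro to phenylsulfanyl on the shared core

The source may report more compounds than this note shows. Statements on the series, on what has been measured and on what is new or still open speak of the compounds shown alone.

Measured so far:
compound 1 `c1ccc(Sc2ncnc3[nH]cnc23)cc1`: 0%
compound 2 `Clc1ncnc2c1ncn2Cc1ccccc1`: 0%

In an assay on isolated protein for inhibition of RAC-alpha serine/threonine-protein kinase (Homo sapiens), tested at 30 uM (a higher number here means more inhibition at the concentration tested (going by the name of the read-out), a lower number less inhibition), compound 1 gives 0%. In this assay compound 2 gives 0%, level with compound 1 at the digits given, within the scatter. Compound 3 `c1ccc(Cn2cnc3c(Sc4ccccc4)ncnc32)cc1` is not yet measured in this assay. Its change from compound 2 is phenylsulfanyl in place of chloro on an aromatic carbon: chloro leaves and phenylsulfanyl enters on the aromatic carbon. Among the measured compounds shown here, no step between measured compounds is available. Given that compound 1, which already carries phenylsulfanyl, gives 0%, no step beyond the scatter is expected from compound 2 to compound 3, a number 2 percentage points higher from compound 2 to compound 3 (within the scatter). Compound 3 is estimated at 2% in this assay, with a range from -10% to 20%.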

Compound 3, a percentage reported as inhibition, at one concentration (the size of the read-out at that concentration, not a potency): 1%
Compound 3: middle estimate off by 1 percentage points, on the high side, and the stated range covers the measured number.
By their numbers in this assay, from the lowest: compounds 1, 2 and 3 (each within the scatter of the next).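

In this assay, neither phenylsulfanyl in place of chloro on an aromatic carbon (a number 1 percentage points higher from compound 2 to compound 3 (within the scatter)) nor benzyl in place of hydrogen on an aromatic nitrogen (a number 1 percentage points higher from compound 1 to compound 3 (within the scatter)) moves the read-out beyond the scatter. Carrying both groups on the shared core, compound 3 therefore gives no sign that either group adds inhibition at the concentration tested. Nothing at hand accounts for this flat result. Still open, going by these compounds, is whether an amine or a carboxylic acid in place of phenylsulfanyl, or a longer chain in place of benzyl, would give a read-out beyond the scatter.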